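This account rests on a few compounds, and the source may have more. Where it says the series, first, only, none or still open, it means among the compounds named here.

Compound 1 `CCc1cccc2c(OC)c(-c3occ(C)c3COC)ccc12` gives > 10 ug/mL in a functional assay on DU-145 cells (Homo sapiens) for cytotoxicity, read by MTT assay, with a stated time of 72 h (on this read-out lower numbers stand for an effect already at smaller amounts and higher numbers for an effect only at larger amounts of compound), which is a limit of the assay and not a number.
Compound 2 `CCc1cccc2c(OC)c(-c3occ(C)c3COC(C)=O)ccc12` gives > 10 ug/mL in this assay, again a limit and not a number.
Compound 3 `CCOc1c(-c2occ(C)c2COC)ccc2c(CC)cccc12` gives > 10 ug/mL in this assay, again a limit and not a number.

Compound 4 `CCOc1c(-c2occ(C)c2COC(C)=O)ccc2c(CC)cccc12` has not yet been measured in this assay. It arises from compound 3 by one change: acetyl in place of methyl on an oxygen on a saturated carbon. The same change is already on record between two measured compounds, where it reads (acetyl in place of methyl on an oxygen on a saturated carbon), and the step it made there is a step that the two limits leave unreadable from compound 1 to compound 2; its size stays hidden because of the limit of > 10 ug/mL in this assay, at which 3 of the 3 values shown sit. The two cores differ in one respect, (methyl in place of hydrogen on a saturated chain carbon bound to an oxygen on an aromatic ring), and the place of the acetyl-for-methyl change is described in the same words in both pairs, so it counts as the same change. With all three measured values sitting at a limit, the expectation for compound 4 rests only on that. The step that the estimate means is a step that the limit leaves unreadable from compound 3 to compound 4, and it is expected to be unreadable in the same way. Compound 4 is expected to give 20 ug/mL, within 10 ug/mL and 60 ug/mL, most likely reported again as a limit.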

Compound 4, concentration for half-maximal effect: > 10 ug/mL
Compound 4: only a limit was reported; the forecaster's own chance of this, stated with the estimate: 85%; the middle value does not contradict the limit.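

The steps from compound 3 to compound 4 and from compound 2 to compound 4 cannot be read, and the reason is shared by all four compounds: the limit of > 10 ug/mL in this assay, at which 4 of the 4 values shown sit. The compounds shown leave open how large either change, acetoxymethyl for methoxymethyl or the added methyl, really is in this assay, and at what amount any of them would reach half-maximal effect.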